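Sulfone to Sulfonamide in a Kinase-Type Scaffold

The source may hold more compounds than are shown below. What is called first, only, known or untested is meant among the compounds shown, and "the series" means these compounds.

Compound 1 `Cn1c(=O)c(S(=O)(=O)c2ccc(F)cc2[N+](=O)[O-])cc2cnc(Nc3ccc4[nH]ccc4c3)nc21` is the stronger of the two measured compounds: in a functional assay on K562 cells (Homo sapiens) for inhibition, read by trypan blue exclusion, with a stated time of 72 h (a higher number here means a weaker inhibitor, a lower number a stronger inhibitor), compound 1 gives 900 nM. Compound 2 `Cn1c(=O)c(S(=O)(=O)c2ccc(F)cc2)cc2cnc(Nc3ccc4cc[nH]c4c3)nc21` differs from compound 1 in more than one place; in this assay compound 2 gives 10000 nM, a gap that lies beyond the usual scatter, so compound 1 stands at the lower and better end of what has been seen. Compound 3 `Cn1c(=O)c(S(=O)(=O)Nc2ccc(F)cc2)cc2cnc(Nc3ccc4[nH]ccc4c3)nc21` is the next compound to be measured. It differs from compound 1 by (4-fluorophenyl)amino in place of 4-fluoro-2-nitrophenyl on a sulfonyl sulfur. Going by the values given here, no single-point step between measured compounds is available to anchor this change, so any expectation rests on the two values alone. The step of a 2.8-fold higher number from compound 1 to compound 3 (0.44 log units; beyond the scatter) is expected to be moderate and toward a weaker inhibitor. Compound 3 is therefore expected to give about 2500 nM in this assay, with a plausible range from 700 nM to 9000 nM.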

Compound 3, half-maximal inhibitory concentration: 5000 nM
Beside the measured number, compound 3's estimate is 2.0-fold (0.30 log units) below it; low and high end bracket the measured number.
By their numbers in this assay, from the lowest: compound 1; then compounds 3 and 2 (each within the scatter of the next).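

In this assay, going by these compounds alone, putting (4-fluorophenyl)amino in place of 4-fluoro-2-nitrophenyl on the sulfonyl sulfur gives a 5.6-fold higher number from compound 1 to compound 3 (0.74 log units; beyond the scatter), the only step here that changes a single place. It shows that this position responds to the change, though modestly, and that the sulfonyl sulfur can carry a nitrogen-linked aryl group with activity still measurable in these cells. No supporting data explain the size or direction of this step.

Because the nitro group leaves as the amino nitrogen enters, the step cannot say how much each contributes. Also open, on these data alone, is how the reading would shift with a saturated amine such as morpholine on the sulfonyl sulfur, or with a methyl group on the sulfonamide nitrogen.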